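The source may report more compounds than this note shows. Statements on the series, on what has been measured and on what is new or still open speak of the compounds shown alone.

Compound 1, `CCCCCCCCCCCCCCC[C@H](O)C[C@@H](O)C[C@@H](O)C[C@@H](O)C[C@@H](O)CCO`, in a functional assay on MCF7 cells (Homo sapiens) for cytotoxicity, read by MTT assay, with a stated time of 72 h (a lower number here means a stronger inhibitor, a higher number a weaker inhibitor), gives > 500000 nM, which is a limit of the assay and not a number.
Compound 2, `CCCCCCCCCCCCCCC[C@@H](C[C@H](O)C[C@H](O)C[C@H](O)C[C@H](O)C[C@@H]1CC=CC(=O)O1)OC(C)=O`, gives 13300 nM.
Compound 3, `CCCCCCCCCCCCCCC[C@H](C[C@H](O)C[C@H](O)C[C@H](O)C[C@H](O)C[C@@H]1CC=CC(=O)O1)OC(C)=O`, gives 9000 nM.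

Compound 1 thus stands only at the limit, with no number of its own. Within the data shown here, the one measured step, a 1.5-fold lower number from compound 2 to compound 3 (0.17 log units; within the scatter), concerns a change of configuration alone and does not bear on the change toward compound 4, `CCCCCCCCCCCCCCC[C@H](O)C[C@@H](O)C[C@@H](O)C[C@@H](O)C[C@@H](O)C[C@H]1CC=CC(=O)O1`, which is a group of 7 heavy atoms (5 carbon, 2 oxygen; one six-membered non-aromatic ring with 1 hetero atom) in place of a group of 2 heavy atoms (1 carbon, 1 oxygen; no ring), on a saturated chain carbon, two bonds along the chain from an oxygen on a saturated carbon. Compound 2 and compound 3, both carrying the entering group, give numbers in this assay, though compound 4 also differs from them elsewhere in the chain, a difference the data do not cover. A large downward step is expected, an at least 41-fold lower number from compound 1 to compound 4 (1.61 log units; beyond the scatter). Compound 4 is estimated at 12000 nM, with a range from 3000 nM to 60000 nM.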

Compound 4, half-maximal inhibitory concentration: 8100 nM
The estimate for compound 4 lay 1.5-fold (0.17 log units) above the measured number; the measured number falls inside the stated range.
By their numbers in this assay, from the lowest: compounds 4, 3 and 2 (each within the scatter of the next). At a limit, above all of these: compound 1.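

Among these compounds, compound 4 is the first compound that differs from compound 1 in this one place alone, at a saturated chain carbon, two bonds along the chain from an oxygen on a saturated carbon. There, the six-membered non-aromatic ring in place of hydroxymethyl gives, in this assay, an at least 61-fold lower number from compound 1 to compound 4 (1.79 log units; beyond the scatter). The size of this step is only a bound, because compound 1 has a limit of the assay and not a number: the limit of > 500000 nM in this assay, at which 1 of the 4 values shown sits.

From the compounds shown here alone, whether a carboxylic acid or an amine at this place would give a similar number stays open. So does the effect of a longer chain.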